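Compound 4: 4-Methoxyphenyl for 3-Bromophenyl

A few compounds are considered here, and "the series" means these few. Any claim that something is new, unique, unknown or untested is made for them only; others in the source may bear on it.

Measured in a functional assay on HepG2 cells (Homo sapiens) for cytotoxicity, read by MTT assay, with a stated time of 72 h; a higher number here means a weaker inhibitor, a lower number a stronger inhibitor:
compound 1 `O=C(N/N=C/c1cccc(Br)c1)Nc1cc2c(Nc3ccc(F)c(Cl)c3)ncnc2cc1O[C@H]1CCOC1`: 32300 nM
compound 2 `O=C(N/N=C/c1ccc(O)cc1O)Nc1cc2c(Nc3ccc(F)c(Cl)c3)ncnc2cc1O[C@H]1CCOC1`: 4530 nM
compound 3 `COc1cc2ncnc(Nc3ccc(F)c(Cl)c3)c2cc1NC(=O)N/N=C/c1cccc(Br)c1`: "not active" (no number reported)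

In this assay compound 3 has no number, so it offers no value to step from. Compound 4 `COc1ccc(/C=N/NC(=O)Nc2cc3c(Nc4ccc(F)c(Cl)c4)ncnc3cc2OC)cc1` differs from it in one place: 4-methoxyphenyl in place of 3-bromophenyl on a carbon with a double bond to nitrogen. Going by the values given here, one measured step bears on this change: a 7.1-fold lower number from compound 1 to compound 2 (0.85 log units; beyond the scatter). There, 3-bromophenyl also left, but a different group entered, on the core of compound 1. On that step alone, a modest move towards a lower number is expected, though its size from compound 3 cannot be stated. Compound 4 is estimated at 20000 nM, with an expected range of 6000 nM to 70000 nM.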

Compound 4, half-maximal inhibitory concentration: 21300 nM
The estimate for compound 4 lay 1.1-fold (0.03 log units) below the measured number, within the range that was stated.
By their numbers in this assay, from the lowest: compound 2; then compounds 4 and 1 (each within the scatter of the next).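

Going by these compounds alone, compound 3 has no number in this assay so no step to compound 4 can be read. The compounds shown leave open how far 4-methoxyphenyl in place of 3-bromophenyl moves the number on this core. No evidence bears on this result.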